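Amide nitrogen substituents in an antiproliferative series

The source may hold more compounds than are shown below. What is called first, only, known or untested is meant among the compounds shown, and "the series" means these compounds.

Compound 1 `CCn1c(C(=O)N[C@H](C)C(=O)OC)ccc1C(CC)(CC)c1ccc(OCS(=O)(=O)c2ccccc2)c(C)c1` has been measured in a functional assay on PC-3 cells (Homo sapiens) for antiproliferative activity, read by MTT assay, with a stated time of 24 h; on this read-out higher numbers stand for weaker inhibition and lower numbers for stronger inhibition. In this assay compound 1 gives only a limit, > 50000 nM, so no number stands for it. Compound 2 `CCn1c(C(=O)NCCNC(=O)OC(C)(C)C)ccc1C(CC)(CC)c1ccc(OCS(=O)(=O)c2ccccc2)c(C)c1` likewise gives only a limit in this assay, > 50000 nM. Among the compounds with values here, the one measured step, a step that the two limits leave unreadable from compound 1 to compound 2, therefore cannot be sized. Taken together there is the limit of > 50000 nM in this assay, at which 2 of the 2 values shown sit; every value so far is a limit, and no step in either direction has been read.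

Compound 3 `CCN(CC)CCNC(=O)c1ccc(C(CC)(CC)c2ccc(OCS(=O)(=O)c3ccccc3)c(C)c2)n1CC` differs from compound 1 at a single place: 2-(diethylamino)ethyl in place of 1-(methoxycarbonyl)ethyl on an amide-type nitrogen. Within the data shown here, no measured step bears on this change. Among the measured compounds shown here, the only step known concerns a different group on the same amide nitrogen and is itself unreadable, so it gives neither size nor direction to lean on. With both known compounds at the limit, the working expectation is that compound 3 will again sit at or near that limit, though a readable number cannot be ruled out. Compound 3 is expected at 50000 nM, within a range from 10000 nM to 200000 nM. The step implied by this estimate is a number no higher from compound 1 to compound 3 (the limit leaves the size open).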

Compound 3, half-maximal inhibitory concentration: 7130 nM
Compound 3: middle estimate off by 7.0-fold (0.85 log units), on the high side; the whole stated range lies above it.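

Notes on the amide-type nitrogen: the substituent at this place can bring a compound off the limit in this assay and give a readable number, which the earlier compounds, both sitting at a limit, could not show. 2-(Diethylamino)ethyl in place of 1-(methoxycarbonyl)ethyl gives an at least 7.0-fold lower number from compound 1 to compound 3 (0.84 log units; beyond the scatter) and so sets a first lower bound on what this place can do. With the ethyl chain kept, diethylamino in place of (tert-butoxycarbonyl)amino gives an at least 7.0-fold lower number from compound 2 to compound 3 (0.84 log units; beyond the scatter) as the result of the end group, so the chain alone does not carry the number, and both steps remain lower bounds, as compound 3 alone stands clear of the limit: the limit of > 50000 nM in this assay, at which 2 of the 3 values shown sit.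

Going by these compounds, whether the amine in the diethylamino group is what matters stays open, since a plain pentyl chain or a methoxy end on the same chain would be needed to separate the amine from the bulk of the end group. Also open, on these data alone, is whether a dimethylamino end, a piperidine ring or a longer chain carrying the diethylamino group would move the number further in either direction.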